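The source may hold more compounds than are shown below. What is called first, only, known or untested is meant among the compounds shown, and "the series" means these compounds.

Of the compounds shown here, two have been measured in a functional assay on HeLa cells (Homo sapiens) for inhibition, read by MTT assay, with a stated time of 72 h; on this read-out lower numbers stand for stronger inhibition and higher numbers for weaker inhibition. Compound 1 `Cc1noc(C)c1-c1cnc(N)c(Oc2ccc(C(=O)Nc3cccc(Cl)c3)cc2)n1` gives 1340 nM in this assay. Compound 2 `Cn1cc(-c2cnc(N)c(Oc3ccc(C(=O)Nc4cccc(Cl)c4)cc3)n2)cn1`, in which 1-methyl-1H-pyrazol-4-yl replaces 3,5-dimethyl-1,2-oxazol-4-yl on an aromatic carbon, gives 4460 nM in this assay. That step is a 3.3-fold higher number from compound 1 to compound 2 (0.52 log units; beyond the scatter). Compound 2 therefore stands at the higher of the two numbers, which means the weaker inhibition. Compound 3 `Cn1cc(-c2cnc(N)c(Oc3ccc(C(=O)Nc4ncccc4Cl)cc3)n2)cn1` differs from compound 2 in one place: 3-chloropyridin-2-yl in place of 3-chlorophenyl on an amide-type nitrogen. Among the compounds with values here, no measured step touches this part of the molecule; the only step known concerns the other end of the shared core, so nothing measured speaks to the size or direction of this change. The expectation for compound 3 in this assay is therefore a step of a 1.0-fold higher number from compound 2 to compound 3 (0.00 log units; within the scatter), that is, no shift beyond the scatter. Compound 3 is thus estimated at 4500 nM, within a range from 1500 nM to 13500 nM.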

Compound 3, half-maximal inhibitory concentration: 36100 nM
Beside the measured number, compound 3's estimate is 8.0-fold (0.90 log units) below it, and the stated range ends below it.
By their numbers in this assay, from the lowest: compound 1; then compound 2; then compound 3.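

The group on the amide-type nitrogen clearly matters in this assay: putting 3-chloropyridin-2-yl in place of 3-chlorophenyl gives an 8.1-fold higher number from compound 2 to compound 3 (0.91 log units; beyond the scatter) and thus weaker inhibition. Within the data shown here, this step is larger than the one earlier step, which lay at the other end of the shared core. The two groups have the same number of heavy atoms and differ only in that one ring carbon is exchanged for a nitrogen, which counts as one added hydrogen-bond acceptor, yet even this small exchange shifts the result well beyond the scatter, and no measurement shown here explains why.

As far as these compounds go, whether the same exchange would also weaken compound 1, which carries 3,5-dimethyl-1,2-oxazol-4-yl, stays open. Also open, from the compounds shown here alone, is what an unsubstituted phenyl or a 3-methylphenyl on the amide-type nitrogen would give, which would show how much the chlorine itself contributes.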